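This account rests on a few compounds, and the source may have more. Where it says the series, first, only, none or still open, it means among the compounds named here.

Measured so far:
Compound 1 `C(=C/c1ccccc1)\C(=N\Nc1nncc2ccccc12)c1ccccc1` gives 1.3 nM
Compound 2 `O=S(=O)(Nc1ncccn1)c1ccc(Nc2nncc3ccccc23)cc1` gives 45 nM

In a functional assay on DU-145 cells (Homo sapiens) for antiproliferative activity, read by sulforhodamine B assay, with a stated time of 72 h (on this read-out lower numbers stand for stronger inhibition and higher numbers for weaker inhibition), compound 2 at 45 nM holds the higher of the two numbers, which makes it the weaker inhibitor, and its gap to compound 1 lies beyond the usual scatter. These two compounds differ in more than one place, so that gap cannot be read as the effect of a single change.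

Compound 3 `Cc1cc(NS(=O)(=O)c2ccc(Nc3nncc4ccccc34)cc2)no1` differs from compound 2 in one place, counted as 5-methyl-1,2-oxazol-3-yl in place of pyrimidin-2-yl on a sulfonamide nitrogen on a sulfonamide nitrogen: 5-methyl-1,2-oxazol-3-yl in place of pyrimidin-2-yl. Going by the values given here, no measured pair shows this swap, so any forecast is loose. Both groups are aromatic rings with hetero atoms, and the expected step is small, probably none beyond the scatter, with a slight lean towards a higher number. The estimate means a 1.3-fold higher number from compound 2 to compound 3 (0.12 log units; within the scatter) as the expected step. Compound 3 is estimated at 60 nM within an expected range of 15 nM to 240 nM.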

Compound 3, half-maximal inhibitory concentration: 35 nM
Beside the measured number, compound 3's estimate is 1.7-fold (0.23 log units) above it, and the stated range covers the measured number.
By their numbers in this assay, from the lowest: compound 1; then compounds 3 and 2 (each within the scatter of the next).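

In this assay, putting 5-methyl-1,2-oxazol-3-yl in place of pyrimidin-2-yl on a sulfonamide nitrogen brings a 1.3-fold lower number from compound 2 to compound 3 (0.11 log units; within the scatter), so the two groups cannot be told apart here. Going by these compounds alone, this is the first single-place comparison, and it shows that a five-membered aromatic ring can stand in for a six-membered one at this position with no step beyond the scatter, while the counts of heavy atoms, donors and acceptors stay the same. No measurement at hand explains this result.

On these data alone, both groups are aromatic rings, so it remains open how a simple methyl or a short chain ending in an amine would read at this sulfonamide nitrogen. Compound 1 differs from compound 2 and compound 3 in more than one place, so which of its features goes with its lower number also stays unresolved.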